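The source may hold more compounds than are shown below. What is called first, only, known or untested is meant among the compounds shown, and "the series" means these compounds.

Measured so far:
Compound 1, `CCc1ccc(-c2nc3c(c(C)nn3-c3ccccc3)c(-c3ccccc3[N+](=O)[O-])c2C#N)cc1`: > 20000 nM in an ADME assay on BJ cells (Homo sapiens) for cytotoxicity, with a stated time of 72 h (on this read-out higher numbers stand for an effect only at larger amounts of compound and lower numbers for an effect already at smaller amounts), a limit of the assay.
Compound 2, `C#Cc1ccccc1-c1c(C#N)c(-c2ccc(CC)cc2)nc2c1c(C)nn2-c1ccccc1`: > 20000 nM, again a limit.
Compound 3, `Cc1nn(-c2ccccc2)c2nc(-c3ccc(C(C)C)cc3)c(C#N)c(-c3ccccc3O)c12`: 22600 nM.

The three compounds share one core and differ only in the groups hung on the two phenyl rings. Among the compounds with values here, compound 3 gives the only actual number in this assay; the other two entries are limits. It therefore stands alone as the sole measured point, with nothing to rank it against. Within the data shown here, the one step between measured compounds, from compound 1 to compound 2, a step that the two limits leave unreadable from compound 1 to compound 2, concerns ethynyl in place of nitro and sits between two limits, so its size cannot be read. the limit of > 20000 nM in this assay, at which 2 of the 3 values shown sit, is all that the remaining entries offer.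

Compound 4, `Cc1nn(-c2ccccc2)c2nc(-c3ccc(S(C)(=O)=O)cc3)c(C#N)c(-c3ccccc3O)c12`, is compound 3 changed by methylsulfonyl in place of isopropyl on an aromatic carbon. Among the measured compounds shown here, no measured step touches this change, and the single readable value of compound 3 gives no direction. The author therefore expects the step of a 1.1-fold higher number from compound 3 to compound 4 (0.03 log units; within the scatter) to stay within the scatter of this assay. For compound 4 the estimate is 24000 nM, with a range from 12000 nM to 50000 nM, and a real chance that only a limit is reported.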

Compound 4, half-maximal effective concentration: > 20000 nM
Compound 4 ended at the assay's limit; the forecaster's own chance of this, stated with the estimate: 55%; the middle value is on the limit's open side.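

In this assay compound 4 gives > 20000 nM, which is a limit of the assay. Within the data shown here, no new step can therefore be read between compound 3 and compound 4, which differ by methylsulfonyl in place of isopropyl. How far any of these changes moves the read-out stays open, with most entries sitting at one bound: the limit of > 20000 nM in this assay, at which 3 of the 4 values shown sit.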